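From isobutyl to tert-butyl on the amine nitrogen

A few compounds are considered here, and "the series" means these few. Any claim that something is new, unique, unknown or untested is made for them only; others in the source may bear on it.

- compound 1 `CC(C)=CCc1cc(C(=O)Nc2cc3ccc(OCC4CCCN(C)C4)c(C)c3oc2=O)ccc1O` gives 1300 nM
- compound 2 `CCN(CC)CCCOc1ccc2cc(NC(=O)c3ccc(O)c(CC=C(C)C)c3)c(=O)oc2c1C` gives 4900 nM
- compound 3 `CC(C)=CCc1cc(C(=O)Nc2cc3ccc(OCCCNCC(C)C)c(C)c3oc2=O)ccc1O` gives 1030 nM

In a functional assay on SK-BR-3 cells (Homo sapiens) for antiproliferative activity (on this read-out lower numbers stand for stronger inhibition and higher numbers for weaker inhibition), compound 3 at 1030 nM lies within the scatter of compound 1 and clearly under compound 2. Compound 4 `CC(C)=CCc1cc(C(=O)Nc2cc3ccc(OCCCNC(C)(C)C)c(C)c3oc2=O)ccc1O` differs from it by tert-butyl in place of isobutyl on an amine nitrogen with tert-butyl in place of isobutyl on an amine nitrogen. Within the data shown here, two measured steps bear on this. The step of a 4.8-fold lower number from compound 2 to compound 3 (0.68 log units; beyond the scatter) shows that the group on the nitrogen can move the number, while the step of a 1.3-fold lower number from compound 1 to compound 3 (0.10 log units; within the scatter) shows a different amine leaving it in place. Neither exchanges isobutyl for tert-butyl, so no step beyond the scatter is expected in this assay and the range stays wide. The expected step is a 1.3-fold higher number from compound 3 to compound 4 (0.10 log units; within the scatter) in this estimate. Compound 4 is expected at 1300 nM with an estimated range from 500 nM to 3500 nM in this read-out.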

Compound 4, half-maximal inhibitory concentration: 660 nM
Compound 4: middle estimate off by 2.0-fold (0.29 log units), on the high side; the measured number falls inside the stated range.
By their numbers in this assay, from the lowest: compounds 4, 3 and 1 (each within the scatter of the next); then compound 2.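

In this assay, tert-butyl in place of isobutyl on the amine nitrogen gives a 1.6-fold lower number from compound 3 to compound 4 (0.19 log units; within the scatter), so this rearrangement of the same carbon atoms does not separate the two compounds on this read-out. The tert-butyl amine also stays level with the 1-methylpiperidin-3-yl side chain, at a 2.0-fold lower number from compound 1 to compound 4 (0.29 log units; within the scatter), while the diethylamino side chain remains apart, at a 7.4-fold lower number from compound 2 to compound 4 (0.87 log units; beyond the scatter). From the compounds shown here alone, whether a cyclopropylamine, a pyrrolidine or a longer chain to the nitrogen would hold this level stays open. Nothing available here accounts for these numbers.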